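The source may hold more compounds than are shown below. What is called first, only, known or untested is meant among the compounds shown, and "the series" means these compounds.

Compound 1, `CN1CCC[C@@H]1Cn1nc(Cc2cccc(Cl)c2)c2ccccc2c1=O`, in an assay for binding affinity to Alpha-1A adrenergic receptor (Homo sapiens) (a lower number here means a stronger inhibitor, a higher number a weaker inhibitor), gives 398 nM.
Compound 2, `CN1CCC[C@@H]1Cn1nc(CC2CCCCC2)c2ccccc2c1=O`, in this assay gives only a limit, > 1990 nM.

Compound 2 therefore stands at the edge of what this assay can report: its value is one of the two shown, and it sits at the limit (the limit of > 1990 nM in this assay, at which 1 of the 2 values shown sits), so only a lower bound on its number is known.

Compound 3, `CN1CCC[C@@H]1Cn1nc(Cc2ccc(F)c(F)c2)c2ccccc2c1=O`, is reached from compound 2 by the change (3,4-difluorophenyl in place of cyclohexyl on a saturated chain carbon bound to an aromatic carbon). Among the measured compounds shown here, the one measured step that bears on this is the reverse kind of exchange: an at least 5.0-fold higher number from compound 1 to compound 2 (0.69 log units; beyond the scatter), where an aromatic ring was swapped for cyclohexyl. Going back to an aromatic ring, here 3,4-difluorophenyl rather than 3-chlorophenyl, is expected to recover much of that loss, giving an estimated step of an at least 3.9-fold lower number from compound 2 to compound 3 (0.59 log units; beyond the scatter) toward stronger binding. The estimate for compound 3 is 500 nM, expected to lie between 150 nM and 1990 nM.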

Compound 3, inhibition constant: 200 nM
Beside the measured number, compound 3's estimate is 2.5-fold (0.40 log units) above it, within the range that was stated.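

Putting 3,4-difluorophenyl in place of cyclohexyl on a saturated chain carbon bound to an aromatic carbon gives an at least 9.9-fold lower number from compound 2 to compound 3 (0.99 log units; beyond the scatter) in this assay, so now two different aromatic rings, in compound 1 and compound 3, both outperform the cyclohexyl of compound 2. The true size of that step is unknown, as compound 2 is only a limit: the limit of > 1990 nM in this assay, at which 1 of the 3 values shown sits.

The two aromatic rings cannot be told apart, since exchanging 3-chlorophenyl for 3,4-difluorophenyl gives a 2.0-fold lower number from compound 1 to compound 3 (0.30 log units; within the scatter), so these two halogen patterns read alike here.

From the compounds shown here alone, it remains open whether halogens are needed at all, which unsubstituted phenyl or methoxyphenyl would help to settle, and whether a pyridine ring could stand in for the aromatic ring. Going by these compounds, how a longer chain carrying the ring would read in this assay is also open.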